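Changing the carbonyl group of compound 3

The source may report more compounds than this note shows. Statements on the series, on what has been measured and on what is new or still open speak of the compounds shown alone.

Of the compounds shown here, three sharing one core have been measured in a functional assay on PC-3 cells (Homo sapiens) for antiproliferative activity, read by MTT assay, with a stated time of 72 h; a higher number here means a weaker inhibitor, a lower number a stronger inhibitor: compound 1 (`CCn1c(C(=O)NCCC(=O)OC)ccc1C(CC)(CC)c1ccc(C#CC(O)(CC)CC)c(C)c1`), compound 2 (`CCn1c(C(=O)NCc2ccc(OC)cc2)ccc1C(CC)(CC)c1ccc(C#CC(O)(CC)CC)c(C)c1`) and compound 3 (`CCn1c(C(=O)On2nnc3ccccc32)ccc1C(CC)(CC)c1ccc(C#CC(O)(CC)CC)c(C)c1`). Compound 1 gives 36300 nM. Compound 2 gives > 50000 nM, which is a limit of the assay. Compound 3 gives > 50000 nM, which is also a limit and not a number. Compound 3 therefore stands at the limit of > 50000 nM in this assay, at which 2 of the 3 values shown sit.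

Compound 4 (`CCn1c(C(=O)NCC(=O)O)ccc1C(CC)(CC)c1ccc(C#CC(O)(CC)CC)c(C)c1`) differs from compound 3 in the group on a carbonyl carbon: a group of 5 heavy atoms (2 carbon, 1 nitrogen, 2 oxygen; no ring) in place of a group of 10 heavy atoms (6 carbon, 3 nitrogen, 1 oxygen; one five-membered aromatic ring with 3 hetero atoms, one six-membered aromatic ring of carbon only), on a carbonyl carbon. The measured steps that bear on this also change what that carbonyl carbon carries. They show an at least 1.3-fold higher number from compound 1 to compound 2 (0.13 log units; that floor lies within the scatter) and an at least 1.3-fold higher number from compound 1 to compound 3 (0.13 log units; that floor lies within the scatter). The remaining one shows a step that the two limits leave unreadable from compound 2 to compound 3. None of these compounds carries (carboxymethyl)amino, so the data give no direct size for this exchange.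

Going by the values given here, the expectation rests mainly on compound 1 at 36300 nM, the only measured number in the set. A result close to the limit is expected, and another limit is quite possible. The expected step is an at least 1.1-fold lower number from compound 3 to compound 4 (0.04 log units; that floor lies within the scatter), with no readable change beyond the scatter foreseen. Compound 4 is estimated at 45000 nM, with an expected range from 20000 nM to 100000 nM.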

Compound 4, half-maximal inhibitory concentration: 2250 nM
The estimate for compound 4 lay 20-fold (1.30 log units) above the measured number, and the stated range ends above it.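

In this assay, going by these compounds alone, the group on this carbonyl carbon turns out to be able to move the read-out well beyond the scatter, which the earlier steps could not show: (carboxymethyl)amino gives an at least 22-fold lower number from compound 3 to compound 4 (1.34 log units; beyond the scatter) and an at least 22-fold lower number from compound 2 to compound 4 (1.34 log units; beyond the scatter). Within the data shown here, the only step between two true numbers is a 16-fold lower number from compound 1 to compound 4 (1.21 log units; beyond the scatter), and compound 1 and compound 2 also carry an amide-type nitrogen on this carbonyl carbon, so that nitrogen alone does not go with the low number of compound 4. The two steps from compound 2 and compound 3 are floors and not sizes, because each of these two compounds stands at a limit of the assay: the limit of > 50000 nM in this assay, at which 2 of the 4 values shown sit.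

Compound 1 and compound 4 differ in both the end of the chain and its length, so the compounds shown do not tell whether the free carboxylic acid or the chain length goes with the lower number. A carboxylic acid on the longer chain of compound 1, a methyl ester on the chain of compound 4, or an amine in place of the carboxy group would each bear on that question.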